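The source may report more compounds than this note shows. Statements on the series, on what has been measured and on what is new or still open speak of the compounds shown alone.

Going by the values given here, compound 2 `CC(C)c1noc(N2CCN(C(=O)[C@@H]3CCCN(S(=O)(=O)c4ccc(S(=O)(=O)NC(C)(C)C)cc4)C3)CC2)n1` gives 300 nM in a functional assay on MIA PaCa-2 cells (Homo sapiens) for inhibition, read by MTT assay, with a stated time of 7 days (a higher number here means a weaker inhibitor, a lower number a stronger inhibitor), the second highest of the three numbers measured so far. Compound 3 `CCN(CC)S(=O)(=O)c1ccc(S(=O)(=O)N2CCC[C@@H](C(=O)N3CCN(c4nc(C)no4)CC3)C2)cc1` gives 250 nM in this assay, within the scatter of compound 2, while compound 1 `CCN(CC)S(=O)(=O)c1ccc(S(=O)(=O)N2CCC[C@@H](C(=O)NC3CN(C(=O)NC(C)(C)C)C3)C2)cc1` gives 3400 nM in this assay. Among the compounds with values here, the only step between compounds that differ in a single place, a 14-fold lower number from compound 1 to compound 3 (1.13 log units; beyond the scatter), concerns the carbonyl end of the shared core. Compound 4 `CCC(CC)S(=O)(=O)c1ccc(S(=O)(=O)N2CCC[C@@H](C(=O)N3CCN(c4nc(C(C)C)no4)CC3)C2)cc1` differs from compound 2 at the other end: pentan-3-yl in place of (tert-butyl)amino on a sulfonyl sulfur. No measured step touches the sulfonyl sulfur, so nothing shown bears directly on this change, and no step beyond the scatter is expected in this assay. Compound 4 is therefore estimated to give 400 nM, between 130 nM and 1300 nM, an expected step of a 1.3-fold higher number from compound 2 to compound 4 (0.12 log units; within the scatter).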

Compound 4, half-maximal inhibitory concentration: 50 nM
Compound 4: middle estimate off by 8.0-fold (0.90 log units), on the high side, and the stated range ends above it.
By their numbers in this assay, from the lowest: compound 4; then compounds 3 and 2 (each within the scatter of the next); then compound 1.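

Going by these compounds alone, on the sulfonyl sulfur, pentan-3-yl in place of (tert-butyl)amino gives a 6.0-fold lower number from compound 2 to compound 4 (0.78 log units; beyond the scatter) in this assay, the first measured step at this place, and it lies beyond the scatter. Both groups have 5 heavy atoms, yet the change removes the nitrogen and the 1 hydrogen-bond donor of (tert-butyl)amino. Nothing available explains why the number falls.

This single pair leaves open whether the nitrogen or the carbon branching matters. A cyclopentyl group or a (pentan-3-yl)amino group on the sulfonyl sulfur could separate the two.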